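The source may report more compounds than this note shows. Statements on the series, on what has been measured and on what is new or still open speak of the compounds shown alone.

Compound 1 `COc1cc(Nc2nc3ccccc3nc2S(=O)(=O)c2ccccc2)cc(OC)c1` gives 70 nM in a functional assay on A549 cells (Homo sapiens) for cytotoxicity, read by MTT assay, with a stated time of 72 h; on this read-out lower numbers stand for stronger inhibition and higher numbers for weaker inhibition.
Compound 2 `COc1ccc(S(=O)(=O)c2nc3ccccc3nc2Nc2cc(OC)cc(OC)c2)cc1` gives 12700 nM.
Compound 3 `COc1cc(Nc2nc3ccccc3nc2S(=O)(=O)c2ccc(F)cc2)cc(OC)c1` gives 5450 nM.

The change from compound 1 to compound 2 is methoxy in place of hydrogen on an aromatic carbon, and it made a 180-fold higher number from compound 1 to compound 2 (2.26 log units; beyond the scatter). Compound 4 `COc1cc(Nc2nc3ccccc3nc2S(=O)(=O)c2ccc(F)cc2)cc(OC)c1OC` has not yet been measured. It differs from compound 3 by methoxy in place of hydrogen on an aromatic carbon, the same kind of change, but the place is not identical: in compound 4 the new methoxy is ortho to two methoxy groups as well as para to a large group, whereas in compound 2 it is only para to a large group. The two cores differ by fluoro in place of hydrogen on an aromatic carbon, and that change made a 78-fold higher number from compound 1 to compound 3 (1.89 log units; beyond the scatter). The earlier step was large, but it sits at another place, so less weight rests on it. For compound 4 a smaller step is expected, a 1.7-fold higher number from compound 3 to compound 4 (0.22 log units; within the scatter). Compound 4 is expected at about 9000 nM, most likely between 2500 nM and 35000 nM.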

Compound 4, half-maximal inhibitory concentration: > 50000 nM
Compound 4: a limit, no number; the forecaster's own chance of this, stated with the estimate: 5%; middle value at least 5.5-fold (0.74 log units) away from the limit.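

In this assay compound 4 gives > 50000 nM, which is a limit of the assay and not a number. Methoxy in place of hydrogen on an aromatic carbon therefore gave an at least 9.1-fold higher number from compound 3 to compound 4 (0.96 log units; beyond the scatter), so this change pushed the number the same way on both cores, although the new methoxy sits at a different place on each. This does not show that the change carries over with the same size: the same change on two cores in this assay, a 180-fold higher number (2.26 log units; beyond the scatter) from compound 1 to compound 2 and an at least 9.1-fold higher number (0.96 log units; beyond the scatter) from compound 3 to compound 4; the limit leaves it open whether they differ

The compounds shown leave open how much of the step depends on the core and how much on the place of the methoxy. They also leave open what an amine or a carboxylic acid at the place of the new methoxy in compound 4 would do to the number.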